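Ring stereocentre inversion: from compound 1 to compound 3

This account rests on a few compounds, and the source may have more. Where it says the series, first, only, none or still open, it means among the compounds named here.

Among the measured compounds shown here, compound 1 `O[C@]1(c2ccccn2)CC[C@H](c2ccc(C(F)(F)F)cc2)C1` and compound 2 `C[C@]1(O)C[C@](c2ccnc(C(F)(F)F)c2)([C@H](O)c2ccccn2)C1` are the two measured members of the set. In an ADME assay on liver for metabolic stability, with Liver microsome (Rattus norvegicus) as the target, read by LC-MS, using microsomes, with a stated time of 5 h (on this read-out higher numbers stand for fast clearance and lower numbers for slow clearance), compound 1 gives 1430 mL/min/kg, the highest of the two numbers. Compound 2 gives 83.3 mL/min/kg in this assay, a lower number beyond the scatter from compound 1; the two structures differ in several places, so that gap is not read as a single step. Compound 3 `O[C@@]1(c2ccccn2)CC[C@H](c2ccc(C(F)(F)F)cc2)C1` has not yet been measured. It differs from compound 1 only in configuration: the two compounds have the same atoms and bonds and differ only in configuration as drawn: 1 of 2 stereo elements differ; a stereocentre at a saturated ring carbon is drawn R in compound 1 and S in compound 3. No change between two measured compounds isolates an inversion of this kind, so its effect in this assay is open; a step of about the size of the scatter, in either direction, or none beyond it, is expected. Compound 3 is thus expected to sit near its drawn partner, with an estimate of 1200 mL/min/kg spanning 500 mL/min/kg to 2500 mL/min/kg. The expected step is a 1.2-fold lower number from compound 1 to compound 3 (0.08 log units; within the scatter).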

Compound 3, clearance: 350 mL/min/kg
For compound 3 the middle estimate is 3.4-fold (0.54 log units) above the measured one; measured number below the stated range.
By their numbers in this assay, from the lowest: compound 2; then compound 3; then compound 1.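

In this assay, inverting a stereocentre at a saturated ring carbon gives a 4.1-fold lower number from compound 1 to compound 3 (0.61 log units; beyond the scatter), so configuration at this one position is enough to move the clearance read-out beyond the scatter. Among the compounds shown here, this is the first change in the set that can be read as a single step, since the gap between compound 1 and compound 2 spans several places. The step can be assigned to the inversion because nothing else changes: the fact that compounds 1 and 3 differ only in the configuration as drawn

Going by these compounds, whether the same inversion gives a step of similar direction and size on a core such as that of compound 2 remains open, as does the effect of the second stereocentre, which is drawn alike in compound 1 and compound 3. Also open, on these data alone, is how an amine or a carboxylic acid on the shared core would read in this assay, in either configuration.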